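From ethynyl to 1-benzothiophen-3-yl on the sulfur chain

A few compounds are considered here, and "the series" means these few. Any claim that something is new, unique, unknown or untested is made for them only; others in the source may bear on it.

Measured in an ADME assay on GES1 cells (Homo sapiens) for inhibition, read by MTT assay, with a stated time of 72 h; on this read-out lower numbers stand for stronger inhibition and higher numbers for weaker inhibition:
- compound 1 `Cc1cc(Nc2cc(-c3ccccc3)[nH]n2)n2nc(SCc3cccc(Br)c3)nc2n1`: > 50000 nM (a limit)
- compound 2 `C#CCSc1nc2nc(C)cc(Nc3cc(-c4ccccc4)[nH]n3)n2n1`: 45700 nM

In this assay, among the measured compounds shown here, compound 2, at 45700 nM, holds the only actual number so far. Compound 1 stands at a limit of the assay, > 50000 nM, and this is not a number. Compound 3 `Cc1cc(Nc2cc(-c3ccccc3)[nH]n2)n2nc(SCc3csc4ccccc34)nc2n1` has 1-benzothiophen-3-yl in place of ethynyl on a saturated chain carbon bound to a sulfur. For the measured compounds named here, one measured step bears on this place, where compound 1 carries 3-bromophenyl: an at least 1.0-fold lower number from compound 1 to compound 2 (0.03 log units; that floor lies within the scatter). That step gives no sign of a change beyond the scatter, so none is expected here, though compound 3 may also reach the limit. The estimate is a 1.1-fold higher number from compound 2 to compound 3 (0.04 log units; within the scatter). For compound 3 the expected value is 50000 nM, with an estimated range of 22000 nM to 110000 nM.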

Compound 3, half-maximal inhibitory concentration: 29200 nM
For compound 3 the middle estimate is 1.7-fold (0.23 log units) above the measured one, within the range that was stated.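

In this assay, among the compounds shown here, the step at this position now joins two actual numbers for the first time: a 1.6-fold lower number from compound 2 to compound 3 (0.19 log units; within the scatter). Exchanging ethynyl, with no ring, for 1-benzothiophen-3-yl, with its two aromatic rings and 9 heavy atoms, on a saturated chain carbon bound to a sulfur therefore leaves the read-out within the scatter. The other step, an at least 1.7-fold lower number from compound 1 to compound 3 (0.23 log units; that floor lies within the scatter), starts from a limit of the assay, so only its floor can be read: the limit of > 50000 nM in this assay, at which 1 of the 3 values shown sits.

The compounds shown carry only ethynyl, 3-bromophenyl and 1-benzothiophen-3-yl at this place, so it stays open whether an amine, a carboxylic acid or a longer chain there would move the number beyond the scatter. They also leave open what actual number compound 1 would have.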